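Changing the Sulfur-Linked Ring of Compound 3

The source may report more compounds than this note shows. Statements on the series, on what has been measured and on what is new or still open speak of the compounds shown alone.

In a functional assay on NCI-H1975 cells (Homo sapiens) for inhibition, read by MTT assay, with a stated time of 72 h (on this read-out lower numbers stand for stronger inhibition and higher numbers for weaker inhibition), compound 1 `Cc1csc(Sc2cc(C(F)(F)F)nc(SCc3ccc(C(F)(F)F)cc3)n2)n1` gives 5840 nM, compound 2 `FC(F)(F)c1ccc(CSc2nc(Sc3ncccn3)cc(C(F)(F)F)n2)cc1` gives 14000 nM and compound 3 `FC(F)(F)c1ccc(CSc2nc(Sc3ccccn3)cc(C(F)(F)F)n2)cc1` gives 23900 nM. All three share one core and differ only in the ring carried on a sulfur. Compound 3 cannot be told apart from compound 2, as the record shows a 1.7-fold higher number from compound 2 to compound 3 (0.23 log units; within the scatter). Compound 1 stands clearly apart, with a 4.1-fold higher number from compound 1 to compound 3 (0.61 log units; beyond the scatter) and also a 2.4-fold higher number from compound 1 to compound 2 (0.38 log units; beyond the scatter).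

Compound 4 `Cc1nnc(Sc2cc(C(F)(F)F)nc(SCc3ccc(C(F)(F)F)cc3)n2)s1` brings a new ring to that sulfur: 5-methyl-1,3,4-thiadiazol-2-yl in place of pyridin-2-yl on a sulfur. The entering 5-methyl-1,3,4-thiadiazol-2-yl has not been measured on this core, but its name most resembles the 4-methyl-1,3-thiazol-2-yl of compound 1. Compound 1 differs from compound 3 by a 4.1-fold higher number from compound 1 to compound 3 (0.61 log units; beyond the scatter), so a modest step towards a lower number is expected, though not a large one. The expected change is a 2.8-fold lower number from compound 3 to compound 4 (0.45 log units; beyond the scatter). For compound 4 the estimated value is 8500 nM, within a range of 3500 nM to 20000 nM.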

Compound 4, half-maximal inhibitory concentration: 3060 nM
For compound 4 the middle estimate is 2.8-fold (0.44 log units) above the measured one, outside the stated range (below it).
By their numbers in this assay, from the lowest: compounds 4 and 1 (each within the scatter of the next); then compounds 2 and 3 (each within the scatter of the next).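

For the compounds shown here, the switch to 5-methyl-1,3,4-thiadiazol-2-yl gives the largest step yet seen on this sulfur in this assay, with a 7.8-fold lower number from compound 3 to compound 4 (0.89 log units; beyond the scatter) and a 4.6-fold lower number from compound 2 to compound 4 (0.66 log units; beyond the scatter), so the ring at this position can shift the number by more than the earlier compounds showed. Compound 4 and compound 1 cannot be separated, with a 1.9-fold lower number from compound 1 to compound 4 (0.28 log units; within the scatter), and in the compounds shown the two methyl-bearing rings, compound 1 and compound 4, both sit apart from the unsubstituted rings of compound 2 and compound 3. Nothing available explains this difference between the rings.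

Going by these compounds, what remains open is whether the methyl group or the ring itself carries the effect. On these data alone, it is also open how this position would respond to an ethyl group or a longer chain in place of that methyl, or to an amine or a carboxylic acid on the same ring.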